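The source may report more compounds than this note shows. Statements on the series, on what has been measured and on what is new or still open speak of the compounds shown alone.

Compound 1 `COC(=O)c1sc2ncnc(Nc3cc(C)cn(C)c3=O)c2c1C` and compound 2 `Cc1cc(Nc2ncnc3sc(C(N)=O)c(C)c23)c(=O)n(C)c1` share one core; compound 3 `COC(=O)c1sc2ncnc(Nc3ccc(=O)n(C)c3)c2c1C` and the unmeasured compound 4 `Cc1c(C(N)=O)sc2ncnc(Nc3ccc(=O)n(C)c3)c12` share another. The difference between the two cores is not broken down here.

In an assay on isolated protein for inhibition of MAP kinase-interacting serine/threonine-protein kinase 1 (Homo sapiens), read by ADP-Glo, with a stated time of 10 min (a lower number here means a stronger inhibitor, a higher number a weaker inhibitor), compound 1 gives only a limit, > 10000 nM. Compound 2 likewise gives only a limit in this assay, > 10000 nM. Compound 3 also sits at a limit in this assay, > 10000 nM.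

Between compound 1 and compound 2 the change is amino in place of methoxy on a carbonyl carbon, and the step it made is a step that the two limits leave unreadable from compound 1 to compound 2; its size cannot be read because of the limit of > 10000 nM in this assay, at which 3 of the 3 values shown sit.

Compound 4 carries the same change relative to compound 3, (amino in place of methoxy on a carbonyl carbon), at a place described in the same words as for compound 1 and compound 2.

With every measured value in this series sitting at the limit, the expectation is that compound 4 also reports only a limit in this assay, so the estimated step that the limit leaves unreadable from compound 3 to compound 4 is expected to be unreadable. Compound 4 is therefore estimated at 20000 nM in this assay, with the estimated range running from 5000 nM to 100000 nM.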

Compound 4, inhibition constant: 4510 nM
Estimate against measurement, compound 4: 4.4-fold (0.65 log units) above; measured number below the stated range.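

In this assay, amino in place of methoxy on a carbonyl carbon gives an at least 2.2-fold lower number from compound 3 to compound 4 (0.34 log units; beyond the scatter), so on the core of compound 3 the change produces a readable lowering of the number. On the core of compound 1 the same change leaves a step that cannot be read, and the sizes on the two cores cannot be compared: the limit of > 10000 nM in this assay, at which 3 of the 4 values shown sit. As far as these compounds go, compound 3 gives only a limit, > 10000 nM, so the full size of the step on its core stays unknown, and the series does not show that the change carries over from one core to the other.

From the compounds shown here alone, what a carboxylic acid or a dimethylamino group on that carbonyl carbon would give in this assay remains open on both cores. Also open, going by these compounds, is whether any carbamoyl compound on the core of compound 1 can give a readable value, and so whether the gain seen on the other core depends on the core at all.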